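A few compounds are considered here, and "the series" means these few. Any claim that something is new, unique, unknown or untested is made for them only; others in the source may bear on it.

Compound 1 `Cc1ccccc1-n1nc(C)c2c1NC(=O)[C@H](C)S[C@@H]2c1ccc(-c2ccoc2)cc1` stands lowest of the two compounds measured: in an assay on isolated protein for agonist activity at Bile acid receptor (Homo sapiens), read by AlphaScreen, with a stated time of 30 min (a lower number here means a smaller maximal response, a higher number a larger maximal response), compound 1 gives 40%, while compound 2 `Cc1nn(-c2ccccc2F)c2c1C(c1ccc(Oc3ccccc3)cc1)SC(C)C(=O)N2` gives 72%, a gap that lies beyond the usual scatter. Compound 3 `Cc1ccccc1-n1nc(C)c2c1NC(=O)[C@H](C)S[C@@H]2c1ccc(-c2ccccc2)cc1` differs from compound 1 in a single place: phenyl in place of furan-3-yl on an aromatic carbon. For the measured compounds named here, no pair of measured compounds shows how such a change plays out, so only a modest shift in this assay is expected, with the direction uncertain. The expected step is a number 10 percentage points higher from compound 1 to compound 3 (within the scatter). Compound 3 is therefore estimated at 50%, within a range from 25% to 80%.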

Compound 3, largest response reached (reported as efficacy), in percent of the reference or control that the assay uses: 24%
Estimate against measurement, compound 3: 26 percentage points above; the whole stated range lies above it.
By their numbers in this assay, from the lowest: compound 3; then compound 1; then compound 2.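

Phenyl in place of furan-3-yl, on an aromatic carbon para to a large group, brings a number 16 percentage points lower from compound 1 to compound 3 (beyond the scatter) in this assay. The maximal response therefore depends on which aromatic ring sits at this position, and here the six-membered carbon ring gives less than the furan. Nothing measured here explains this step.

On these data alone, whether a pyridin-3-yl ring, a thiophen-3-yl ring or a carboxylic acid at this position would raise or lower the response stays open.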